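Ester to primary amide on a dihydropyrimidinone scaffold

A few compounds are considered here, and "the series" means these few. Any claim that something is new, unique, unknown or untested is made for them only; others in the source may bear on it.

Measured compounds:
- compound 1, `CC1=C(C(=O)OC(C)(C)C)C(c2ccoc2)NC(=O)N1`: 2%
- compound 2, `CC1=C(C(=O)OC(C)(C)C)C(c2ccsc2)NC(=O)N1`: 1%
- compound 3, `CC1=C(C(=O)OC(C)(C)C)C(c2ccoc2)NC(=O)N1C`: 12%

In an assay on membranes from HeLa cells for displacement of a labelled ligand from adenosine receptor A3 (Homo sapiens), read by scintillation counting, with a stated time of 180 min, tested at 1 uM (a higher number here means more inhibition at the concentration tested (going by the name of the read-out), a lower number less inhibition), compound 1 gives 2%, the second highest of the three numbers, and all three lie within the scatter of one another. Compound 2 has a thiophen-3-yl in place of furan-3-yl on a saturated ring carbon, and the step is a number 1 percentage points lower from compound 1 to compound 2 (within the scatter). Compound 3 carries a methyl in place of hydrogen on an amide-type nitrogen in a ring, with the step of a number 10 percentage points higher from compound 1 to compound 3 (within the scatter).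

Compound 4, `CC1=C(C(N)=O)C(c2ccoc2)NC(=O)N1`, differs from compound 1 by amino in place of tert-butoxy on a carbonyl carbon. Among the measured compounds shown here, neither measured step touches the carbonyl carbon, so no measured step bears directly on this change; both steps elsewhere on the shared core stayed within the scatter. A step of no more than the scatter is therefore expected in this assay, in no particular direction. Compound 4 is expected to give 3%, with a range from -8% to 15%, that is a step of a number 1 percentage points higher from compound 1 to compound 4 (within the scatter).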

Compound 4, a percentage reported as inhibition, at one concentration (the size of the read-out at that concentration, not a potency): 2%
Compound 4: middle estimate off by 1 percentage points, on the high side; measured number inside the range.
By their numbers in this assay, from the lowest: compounds 2, 1, 4 and 3 (each within the scatter of the next, the first and the last beyond it).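

In this assay the step at this position reads no change at the digits printed from compound 1 to compound 4 (within the scatter) with amino in place of tert-butoxy on a carbonyl carbon. Among the compounds shown here, the earlier compounds all carry tert-butoxy here, so this is the first reading at this position, and it shows that replacing tert-butoxy with the much smaller amino leaves the result within the scatter, although compound 1 at 2% and compound 4 at 2% both show so little inhibition that a loss could hardly be seen. No measurement shown here offers an explanation for this result.

Going by these compounds, whether a carboxylic acid, a methyl ester or a dimethylamino group on this carbonyl carbon would read differently remains open. Also open, on these data alone, is how amino behaves alongside the methyl on the ring amide-type nitrogen of compound 3.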